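Methoxy Swapped for Methylimidazolyl: An Expected Potency Estimate

The source may hold more compounds than are shown below. What is called first, only, known or untested is meant among the compounds shown, and "the series" means these compounds.

Compound 1, `CCC(C)c1cc(C)c(C(=O)N=C(N)N)cc1S(C)(=O)=O`, gives 8 nM in a functional assay for inhibition of sodium/hydrogen exchanger (Oryctolagus cuniculus); on this read-out lower numbers stand for stronger inhibition and higher numbers for weaker inhibition.
Compound 2, `COc1cc(C)c(C(=O)N=C(N)N)cc1S(C)(=O)=O`, gives 16 nM in this assay.

Compound 2 holds the higher of the two numbers, yet the gap between them is only a 2.0-fold higher number from compound 1 to compound 2 (0.30 log units; within the scatter), so the two cannot be told apart. Compound 3, `Cc1cc(-n2ccnc2C)c(S(C)(=O)=O)cc1C(=O)N=C(N)N`, has not yet been measured. The change is 2-methyl-1H-imidazol-1-yl in place of methoxy on an aromatic carbon. Among the compounds with values here, the one measured step concerns a different replacement, sec-butyl to methoxy, and is within the scatter, so no measured step bears directly on trading methoxy for a five-membered aromatic ring at this place. The expectation for this assay is therefore a step of no clear direction beyond the scatter, with a wide range to cover the absence of guidance: the step from compound 2 to compound 3 is estimated as a 1.3-fold higher number from compound 2 to compound 3 (0.10 log units; within the scatter). Compound 3 is expected to give 20 nM, within 6 nM to 70 nM.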

Compound 3, half-maximal inhibitory concentration: 29 nM
Compound 3: middle estimate off by 1.5-fold (0.16 log units), on the low side, within the range that was stated.
By their numbers in this assay, from the lowest: compounds 1, 2 and 3 (each within the scatter of the next, the first and the last beyond it).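

In this assay, putting a five-membered aromatic ring at this place, ortho to a methylsulfonyl group, gives a 1.8-fold higher number from compound 2 to compound 3 (0.26 log units; within the scatter), so 2-methyl-1H-imidazol-1-yl and methoxy cannot be told apart here, even though the entering group has 6 heavy atoms and the leaving one has 2. Set against sec-butyl, the same group gives a 3.6-fold higher number from compound 1 to compound 3 (0.56 log units; beyond the scatter), a modest weakening and the only step among these compounds that passes the scatter. Nothing available explains these numbers.

Still open, from the compounds shown here alone, is how a group of a different kind at this place, such as an amine or a carboxylic acid, would compare. The compounds shown also leave open whether the methyl on the new ring matters, as a plain imidazol-1-yl group is not among them.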